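Two More Carbons on the Amine End of a Cinnamanilide

This account rests on a few compounds, and the source may have more. Where it says the series, first, only, none or still open, it means among the compounds named here.

Of the compounds shown here, three sharing one core have been measured in a physicochemical assay for lipophilicity, using the shake flask method, measured as octanol-water partition, at pH 7.4; a lower number here means a more polar compound, a higher number a more lipophilic compound. Compound 1 `CCN(CC)CCCCOc1ccc(/C=C/C(=O)Nc2ccccc2)cc1OC` gives 1.59 in this assay. Compound 2 `COc1cc(/C=C/C(=O)Nc2ccccc2)ccc1OCCCCN1CCCC1` gives 1.6. Compound 3 `COc1cc(/C=C/C(=O)Nc2ccccc2)ccc1OCCCCCN1CCCC1` gives 1.64, which is the highest of the three numbers, although its gap to compound 2 and to compound 1 is within the scatter in both cases. The steps already seen are all small: a number 0.01 log units higher from compound 1 to compound 2 (within the scatter), a number 0.05 log units higher from compound 1 to compound 3 (within the scatter) and a number 0.04 log units higher from compound 2 to compound 3 (within the scatter).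

Compound 4 `COc1cc(/C=C/C(=O)Nc2ccccc2)ccc1OCCCCCCN1CCCCC1` is not yet measured. It differs from compound 3 by (piperidin-1-yl)methyl in place of pyrrolidin-1-yl on a saturated chain carbon, five bonds along the chain from an oxygen on an aromatic ring. The step from compound 2 to compound 3, a single added chain carbon, bears most directly on this change, and it stayed within the scatter; the other two steps, which exchange one amine for another, did likewise. The present change adds two carbons rather than one, so a somewhat larger shift upward is plausible, but nothing measured here supports more than a modest one.

Compound 4 is therefore expected to give 1.8 in this assay, with a range of 1.5 to 2.2. The expected step is a number 0.16 log units higher from compound 3 to compound 4 (within the scatter).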

Compound 4, partition coefficient: 1.77
Estimate against measurement, compound 4: 0.03 log units above, and the stated range covers the measured number.
By their numbers in this assay, from the lowest: compounds 1, 2, 3 and 4 (each within the scatter of the next).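

In this assay the exchange of pyrrolidin-1-yl for (piperidin-1-yl)methyl on a saturated chain carbon, five bonds along the chain from an oxygen on an aromatic ring, gives a number 0.13 log units higher from compound 3 to compound 4 (within the scatter); a group of 7 heavy atoms entering for one of 5, with the ring size and the chain both altered, thus still leaves the read-out inside the scatter. For the compounds shown here, the widest exchanges in the set read the same way, with 2-(piperidin-1-yl)ethyl in place of pyrrolidin-1-yl giving a number 0.17 log units higher from compound 2 to compound 4 (within the scatter) and 2-(piperidin-1-yl)ethyl in place of diethylamino giving a number 0.18 log units higher from compound 1 to compound 4 (within the scatter), so no step among the four compounds is yet printed as beyond the scatter. Nothing at hand offers a reason for the size of these steps.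

The compounds shown leave open how much of the step belongs to the piperidin-1-yl ring and how much to the added chain carbon, since the two change together here. They also leave open whether a longer chain, or another amine such as morpholin-4-yl in the same place, would move the partition coefficient beyond the scatter.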